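The source may hold more compounds than are shown below. What is called first, only, known or untested is meant among the compounds shown, and "the series" means these compounds.

Compound 2 `CC(c1ccc(-c2ccccc2)c(F)c1)c1nnc2n1N=C(c1ccc(OC(F)(F)F)cc1)CS2` is one of two compounds tested in a functional assay on Huh-7 cells (Homo sapiens) for inhibition, read by sulforhodamine B assay, with a stated time of 72 h (a lower number here means a stronger inhibitor, a higher number a weaker inhibitor), where compound 2 gives 8400 nM. Compound 1 `Cc1ccc(C2=Nn3c(nnc3C(C)c3ccc(CC(C)C)cc3)SC2)cc1` gives 5000 nM in this assay; the two values lie within the scatter of each other, so neither stands apart from the other. Compound 3 `CC(c1ccc(-c2ccccc2)c(F)c1)c1nnc2n1N=C(c1ccc(C(F)(F)F)cc1)CS2` differs from compound 2 in one place: trifluoromethyl in place of trifluoromethoxy on an aromatic carbon. Within the data shown here, no measured pair shows this change, so its effect on the numbers is unknown. The step in this assay is expected to stay within the scatter, in either direction, as a 1.2-fold lower number from compound 2 to compound 3 (0.08 log units; within the scatter). Compound 3 is expected to give about 7000 nM, between 2500 nM and 20000 nM.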

Compound 3, half-maximal inhibitory concentration: 9400 nM
Beside the measured number, compound 3's estimate is 1.3-fold (0.13 log units) below it, within the range that was stated.
By their numbers in this assay, from the lowest: compounds 1, 2 and 3 (each within the scatter of the next).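

In this assay, trifluoromethyl in place of trifluoromethoxy on this aromatic carbon, para to a large group, gives a 1.1-fold higher number from compound 2 to compound 3 (0.05 log units; within the scatter). At this position, then, the swap between these two groups, with the rest of the structure held fixed, leaves the number within the scatter. No evidence is at hand that speaks to why the two groups read alike. The compounds shown leave open whether an amine or a carboxylic acid at this position would move the number beyond the scatter, and whether the same swap reads alike on the other side of the molecule.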